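A few compounds are considered here, and "the series" means these few. Any claim that something is new, unique, unknown or untested is made for them only; others in the source may bear on it.

Working notes on the series.

Of the compounds shown here, three on the shared core have been measured in a functional assay on A-431 cells (Homo sapiens) for cytotoxicity, read by MTT assay, with a stated time of 24 h; on this read-out higher numbers stand for weaker inhibition and lower numbers for stronger inhibition. Compound 1 `COc1ccc(/C=C\C(=O)O)c(OCc2cn(-c3ccccc3C(=O)N3CCC(O)C3)nn2)c1CC=C(C)C` gives 31500 nM. Compound 2 `COc1ccc(/C=C\C(=O)O)c(OCc2cn(-c3cccc([N+](=O)[O-])c3)nn2)c1CC=C(C)C` gives 18400 nM. Compound 3 `COc1ccc(/C=C\C(=O)O)c(OCc2cn(-c3ccc(NC(=O)c4ccccc4)cc3)nn2)c1CC=C(C)C` gives 21200 nM. The three numbers form a tight cluster: compound 2 stands at the low end of it, but its gaps to compound 3 and to compound 1 both fall within the usual scatter, so no order among the three is claimed.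

Compound 4 `COc1cccc(-n2cc(COc3c(/C=C\C(=O)O)ccc(OC)c3CC=C(C)C)nn2)c1` has not yet been measured in this assay. It differs from compound 2 in one place: methoxy in place of nitro on an aromatic carbon. Among the compounds with values here, no step between measured compounds of this kind is available, so the effect of swapping the nitro for a methoxy on this ring rests on nothing in the data. Given that the three measured compounds, with quite different groups on this ring, all sit together, the step from compound 2 to compound 4 is expected to be small, with no clear direction beyond the scatter, a 1.2-fold higher number from compound 2 to compound 4 (0.08 log units; within the scatter). The estimate for compound 4 in this assay is 22000 nM, within a range of 9000 nM to 55000 nM.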

Compound 4, half-maximal inhibitory concentration: 23200 nM
Compound 4: middle estimate off by 1.1-fold (0.02 log units), on the low side, within the range that was stated.
By their numbers in this assay, from the lowest: compounds 2, 3, 4 and 1 (each within the scatter of the next).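

Within the data shown here, the first one-place step at this position in this assay is methoxy in place of nitro on an aromatic carbon (a 1.3-fold higher number from compound 2 to compound 4 (0.10 log units; within the scatter)), so this swap on the 3-substituted phenyl leaves the number unresolved from that of compound 2. The earlier compounds shown here differed from one another in more than one place and could not isolate this change; here, nitro and methoxy can be compared directly on the shared core, and the read-out does not separate them. Nothing available explains this result.

Going by these compounds, whether an amine or a carboxylic acid on the same aromatic carbon, or a longer chain such as butoxy in place of methoxy, would give a step beyond the scatter remains open. A single step also leaves open how far this result holds for other groups at this position.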